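The source may report more compounds than this note shows. Statements on the series, on what has been measured and on what is new or still open speak of the compounds shown alone.

In an ADME assay for pharmacokinetics, at pH 7.4 (a lower number here means that the compound disappears faster, a higher number that the compound lasts longer), compound 3 `COc1ccnc(C[S+]([O-])c2nc3cc(OC(F)(F)C(F)F)ccc3[nH]2)c1OC` gives 160 h as the higher of two exact numbers, while compound 1 `COc1ccnc(C[S+]([O-])c2nc3cc(OC(F)F)ccc3[nH]2)c1` gives 51 h and lies clearly lower. Compound 2 `COc1ccnc(C[S+]([O-])c2nc3cc(OCC(F)(F)F)ccc3[nH]2)c1OC` reports > 200 h which is a limit and not a number. Compound 4 `COc1ccnc(C[S+]([O-])c2nc3cc(OC(F)(F)C(F)F)ccc3[nH]2)c1` differs from compound 3 by one change hydrogen in place of methoxy on an aromatic carbon with hydrogen in place of methoxy on an aromatic carbon. Going by the values given here, the one measured step of an at least 1.2-fold lower number from compound 2 to compound 3 (0.09 log units; that floor lies within the scatter) concerns a different place, and its floor lies within the scatter, so it sets no size here. Compound 1 also carries hydrogen on that carbon, alongside a different fluorinated group on oxygen, and its 51 h points downward. In this assay the expected change is a 2.9-fold lower number from compound 3 to compound 4 (0.46 log units; beyond the scatter) which would lie beyond the scatter. Compound 4 is expected near 55 h with an estimated range from 25 h to 120 h as its likely span.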

Compound 4, half-life in the ADME assay: 63 h
Compound 4: middle estimate off by 1.1-fold (0.06 log units), on the low side; measured number inside the range.
By their numbers in the ADME assay, from the lowest: compounds 1 and 4 (each within the scatter of the next); then compound 3. At a limit, above all of these: compound 2.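

Going by these compounds alone, in the ADME assay, compound 3 gives 160 h and compound 4 gives 63 h; hydrogen in place of methoxy gives a 2.5-fold lower number from compound 3 to compound 4 (0.40 log units; beyond the scatter), the first reading of this position with the same fluorinated group on oxygen on both sides. In the ADME assay, difluoromethyl in place of hydrogen on the chain gives only a 1.2-fold higher number from compound 1 to compound 4 (0.09 log units; within the scatter), so with hydrogen on the aromatic carbon, this change in the fluorinated group has no readable effect. In a physicochemical assay for acid dissociation, compound 3 gives 8.08 and compound 4 gives 7.91; hydrogen in place of methoxy gives a number 0.17 log units lower from compound 3 to compound 4 (within the scatter), so the half-life step has no readable counterpart in acid dissociation.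

As far as these compounds go, how an ethoxy group or a chlorine atom on this carbon would behave stays open. The exact standing of compound 2 also stays open because its value is a limit: the limit of > 200 h in the ADME assay, at which 1 of the 4 values shown sits.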